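The compounds below may be only part of what the source reports. "The series", "measured", "known", "first", "only" and "open" are said of these compounds alone.

In a functional assay on HeLa cells (Homo sapiens) for inhibition, read by sulforhodamine B assay (a higher number here means a weaker inhibitor, a lower number a stronger inhibitor), compound 1 (`O=C1C(N2CCC2)=CC(=O)c2c1nc1n2[C@H]2OC[C@@H](O)[C@H]2OC1`) gives > 16000 nM as a limit of the assay, not as a number. Going by the values given here, compound 2 (`O=C1C(Nc2cccc(Cl)c2)=CC(=O)c2c1nc1n2[C@H]2OC[C@@H](O)[C@H]2OC1`), which carries (3-chlorophenyl)amino in place of azetidin-1-yl, gives 7970 nM in this assay and so holds the only true number so far. With no second number beside it, compound 2 cannot yet be placed within a measured range.

Compound 3 (`O=C1C(Nc2cccc(F)c2)=CC(=O)c2c1nc1n2[C@H]2OC[C@@H](O)[C@H]2OC1`) departs from compound 2 in one place (fluoro in place of chloro on an aromatic carbon): fluoro in place of chloro on an aromatic carbon, meta to a large group.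

Among the compounds with values here, only one measured step exists (an at least 2.0-fold lower number from compound 1 to compound 2 (0.30 log units; that floor lies within the scatter)) and it bears on this change only loosely. It replaces a whole group rather than one halogen, and its size is known only as a floor that lies within the scatter. Within the data shown here, no measured step therefore points to a real shift, in either direction, from this swap.

The expected step (a 1.1-fold higher number from compound 2 to compound 3 (0.05 log units; within the scatter)) is small and no larger than the scatter. For compound 3 the estimated value is 9000 nM in this assay with an expected range from 4500 nM to 18000 nM in this read-out.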

Compound 3, half-maximal inhibitory concentration: > 8000 nM
Compound 3: only a limit was reported; the forecaster's own chance of this, stated with the estimate: 20%; the middle value is on the limit's open side.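

In this assay, compound 3 gives > 8000 nM, which is a limit of the assay and not a number. Fluoro in place of chloro on this aromatic carbon thus brings a number no lower from compound 2 to compound 3 (the limit leaves the size open), so this single-atom swap gives no sign of a stronger inhibitor, while how much weaker compound 3 may be, if it is weaker at all, stays unknown. Going by these compounds alone, the step between compound 1 and compound 3 cannot be read, since both of its ends are limits, and compound 2 therefore still holds the only true number among the three.

The compounds shown leave open whether the halogen on this aromatic carbon matters at all, since a single number and two limits cannot show how inhibition responds to a change there. A bromo, methoxy or nitrile group on the same carbon, in place of chloro, could show whether any group there gives a clearly lower number than compound 2 or whether the values stay in this weak range.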